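Inverting one ring stereocentre of compound 1

A few compounds are considered here, and "the series" means these few. Any claim that something is new, unique, unknown or untested is made for them only; others in the source may bear on it.

Compound 1, `COc1cc([C@H]2C[C@@]2(CO)C(=O)Nc2ccccc2)cc(OC)c1OC`: in a functional assay on SW480 cells (Homo sapiens) for cytotoxicity, read by MTT assay, with a stated time of 48 h (on this read-out higher numbers stand for weaker inhibition and lower numbers for stronger inhibition), compound 1 gives > 100000 nM, which is a limit of the assay and not a number.
Compound 2, `COc1cc([C@H]2C[C@@]2(CO)C(=O)NCc2ccc(C)cc2)cc(OC)c1OC`: compound 2 gives > 100000 nM, also a limit.
Compound 3, `CCOC(=O)[C@@]1(C(=O)Nc2ccccc2)C[C@@H]1c1cc(OC)c(OC)c(OC)c1`: compound 3 gives > 100000 nM, again a limit.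

All three measured compounds sit at the same limit, (the limit of > 100000 nM in this assay, at which 3 of the 3 values shown sit). Compound 1 therefore has no number of its own, and nothing on these values separates it from compound 2 or compound 3. Compound 4, `COc1cc([C@H]2C[C@]2(CO)C(=O)Nc2ccccc2)cc(OC)c1OC`, is the unmeasured partner of compound 1. the two compounds have the same atoms and bonds and differ only in configuration as drawn: 1 of 2 stereo elements differ; a stereocentre at a saturated ring carbon is drawn R in compound 1 and S in compound 4

Two measured steps start from compound 1: the change to a 4-methylbenzyl on the amide-type nitrogen, a step that the two limits leave unreadable from compound 1 to compound 2, and the change to an ethoxycarbonyl on a saturated ring carbon, a step that the two limits leave unreadable from compound 1 to compound 3. Within the data shown here, neither step is readable, since both ends rest on limits, and neither concerns a change of configuration, so no measured step bears directly on the move to compound 4. The only guide is that every compound shown so far sits at the limit. Compound 4 is therefore expected to remain there too, with a step of a number no higher from compound 1 to compound 4 (the limit leaves the size open) expected from compound 1. Compound 4 is estimated at 100000 nM, within 30000 nM to 300000 nM, and most likely the assay again reports only a limit.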

Compound 4, half-maximal inhibitory concentration: > 100000 nM
Compound 4: only a limit was reported; the forecaster's own chance of this, stated with the estimate: 85%; the middle value sits exactly at the limit.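

In this assay compound 4 gives > 100000 nM, which is a limit and not a number. Among these compounds, compound 1 also rests on a limit, so no step from compound 1 to compound 4 can be read. The compounds shown leave open whether the configuration at that ring carbon changes this read-out at all, as no compound has a number of its own: the limit of > 100000 nM in this assay, at which 4 of the 4 values shown sit.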